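Fluoro to methyl on the aromatic ring: compound 3

A few compounds are considered here, and "the series" means these few. Any claim that something is new, unique, unknown or untested is made for them only; others in the source may bear on it.

Within the data shown here, in a functional assay on the whole organism for inhibition, with Mus musculus as the target (a lower number here means that less compound is needed, a higher number that more compound is needed for the effect), only two compounds have numbers so far. Compound 1 `CN1Cc2c(N)cccc2C(c2ccc(Cl)cc2)C1` gives 1.6 mg/kg, and compound 2 `CN1Cc2c(N)cccc2C(c2ccc(F)cc2)C1` gives about 3.6 mg/kg, the higher of the two numbers. Compound 3 `Cc1ccc(C2CN(C)Cc3c(N)cccc32)cc1` keeps the shared core and carries methyl in place of fluoro on an aromatic carbon, para to a large group (methyl in place of fluoro on an aromatic carbon).

Among the measured compounds shown here, only one measured step bears on this change, and it concerns the same place: a 2.3-fold higher number from compound 1 to compound 2 (0.35 log units; beyond the scatter), a modest move on exchanging chloro for fluoro. For the measured compounds named here, no measured compound carries methyl, so the evidence is thin and the direction is uncertain. Going by the values given here, with that single step from compound 1 as the only guide to how far this place can move this assay, a small shift towards a lower number is expected, no larger than that step. The expected change is a 1.4-fold lower number from compound 2 to compound 3 (0.16 log units; within the scatter). For compound 3 the estimated value is 2.5 mg/kg, with an expected range of 1 mg/kg to 6 mg/kg.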

Compound 3, dose for half-maximal effect: 1.6 mg/kg
Compound 3: the middle estimate sits 1.6-fold (0.19 log units) above what was measured; low and high end bracket the measured number.
By their numbers in this assay, from the lowest: compounds 1 and 3 (each within the scatter of the next); then compound 2.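

In this assay, the place on an aromatic carbon para to a large group now carries three different groups, and fluoro is the one that stands apart: the exchange for methyl gives a 2.3-fold lower number from compound 2 to compound 3 (0.35 log units; beyond the scatter), while the comparison of chloro with methyl gives no change at the digits printed from compound 1 to compound 3 (within the scatter). The step out of fluoro matches in size the earlier step into it, a 2.3-fold higher number from compound 1 to compound 2 (0.35 log units; beyond the scatter), so compound 2 is set apart from both others by steps beyond the scatter, and a halogen at this place is shown not to be needed for the lower number. Nothing at hand on these compounds accounts for chloro and methyl reading alike here.

The compounds shown leave open how the number moves with other groups at this place, such as methoxy, trifluoromethyl, a longer chain such as propyl, or an amine. Also open, on these data alone, is how far the number depends on the amine of the shared core, which an amide or a hydroxyl in its stead would test.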